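A few compounds are considered here, and "the series" means these few. Any claim that something is new, unique, unknown or untested is made for them only; others in the source may bear on it.

Measured in a functional assay on the whole organism (strain Kunming) with Mus musculus as the target, with a stated time of 0.5 h; a lower number here means that less compound is needed, a higher number that more compound is needed for the effect:
Compound 1 `COc1ccccc1/C=C/C(=O)OC/C=C/c1cc(OC)c(OC)cc1OC` gives 780 umol/kg
Compound 2 `COc1cc(OC)c(OC)cc1/C=C/COC(=O)/C=C/c1ccccc1C(F)(F)F` has only the limit > 710 umol/kg
Compound 3 `COc1cc(OC)c(OC)cc1/C=C/COC(=O)/C=C/c1ccc(F)cc1` has only the limit > 805 umol/kg

Compound 3 therefore has no exact place on the scale, only the limit > 805 umol/kg. Compound 4 `COc1cccc(/C=C/C(=O)OC/C=C/c2cc(OC)c(OC)cc2OC)c1` carries 3-methoxyphenyl in place of 4-fluorophenyl on a double-bonded chain carbon bound to a double-bonded chain carbon.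

The closest measured change is an at least 1.0-fold higher number from compound 1 to compound 3 (0.01 log units; that floor lies within the scatter), which swaps 2-methoxyphenyl for 4-fluorophenyl. The other two steps give no usable size: a step that the limit leaves unreadable from compound 1 to compound 2 and a step that the two limits leave unreadable from compound 2 to compound 3.

Compound 1 also carries a methoxyphenyl group and gives 780 umol/kg, so a similar number is expected for compound 4. The expected change is an at least 1.0-fold lower number from compound 3 to compound 4 (0.03 log units; that floor lies within the scatter), with no step beyond the scatter expected in either direction. For compound 4 the estimate is 750 umol/kg, with an expected range of 380 umol/kg to 1300 umol/kg.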

Compound 4, dose for half-maximal effect: 647 umol/kg
Compound 4: the middle estimate sits 1.2-fold (0.06 log units) above what was measured, within the range that was stated.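

With 3-methoxyphenyl in place of 2-methoxyphenyl on a double-bonded chain carbon bound to a double-bonded chain carbon, compound 4 gives a second exact number in this assay, and the change leaves a result within the scatter: a 1.2-fold lower number from compound 1 to compound 4 (0.08 log units; within the scatter). Compound 2 and compound 3 have only limits, so the steps to compound 4 are floors, and both stay within the scatter: an at least 1.0-fold lower number from compound 2 to compound 4 (0.04 log units; that floor lies within the scatter) and an at least 1.2-fold lower number from compound 3 to compound 4 (0.09 log units; that floor lies within the scatter). So moving the methoxy group around the ring shifts nothing readable here.

On these data alone, whether an aminophenyl or carboxyphenyl group at this place would move the number beyond the scatter stays open.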